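From methoxy to isopropyl: an antiproliferative estimate

This account rests on a few compounds, and the source may have more. Where it says the series, first, only, none or still open, it means among the compounds named here.

Compound 1, `CNC(=O)c1ccccc1Oc1nc(Nc2ccccc2F)ncc1Br`: in a functional assay on MCF7 cells (Homo sapiens) for antiproliferative activity, read by MTT assay, with a stated time of 24 h (a lower number here means a stronger inhibitor, a higher number a weaker inhibitor), compound 1 gives > 50000 nM, a limit of the assay rather than a number.
Compound 2, `CNC(=O)c1ccccc1Oc1nc(Nc2ccc(C)cc2C)ncc1Br`: in this assay compound 2 gives 44700 nM.
Compound 3, `CNC(=O)c1ccccc1Oc1nc(Nc2cccc(OC)c2)ncc1Br`: in this assay compound 3 gives 18200 nM.

All three share one core and differ only in the ring attached to the nitrogen. Compound 3 has the lowest of the two numbers given; the step of a 2.5-fold lower number from compound 2 to compound 3 (0.39 log units; beyond the scatter) is modest, and the step of an at least 2.7-fold lower number from compound 1 to compound 3 (0.43 log units; beyond the scatter) is at least modest, while an at least 1.1-fold lower number from compound 1 to compound 2 (0.04 log units; that floor lies within the scatter) stays within the scatter. Compound 4, `CNC(=O)c1ccccc1Oc1nc(Nc2cccc(C(C)C)c2)ncc1Br`, is the next in this series: isopropyl in place of methoxy on an aromatic carbon.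

For the measured compounds named here, no measured step swaps one such group for another of this kind, so the steps above only show that changing the ring attached to the nitrogen has moved the number by modest amounts at most. In this assay compound 4 is therefore expected to sit close to compound 3, with a step of a 1.1-fold higher number from compound 3 to compound 4 (0.04 log units; within the scatter) that is not expected to go clearly beyond the scatter in either direction. The estimate for compound 4 is 20000 nM, within a range from 7000 nM to 55000 nM.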

Compound 4, half-maximal inhibitory concentration: 26500 nM
Compound 4: the middle estimate sits 1.3-fold (0.12 log units) below what was measured; measured number inside the range.
By their numbers in this assay, from the lowest: compounds 3, 4 and 2 (each within the scatter of the next, the first and the last beyond it). At a limit, above all of these: compound 1.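

For the compounds shown here, on an aromatic carbon meta to a large group, methoxy and its hydrogen-bond acceptor can give way to the all-carbon isopropyl with only a 1.5-fold higher number from compound 3 to compound 4 (0.16 log units; within the scatter) in this assay, the first step here that changes this group alone. Compound 4 also does not separate from the 2,4-dimethylphenyl analogue, with a 1.7-fold lower number from compound 2 to compound 4 (0.23 log units; within the scatter), although compound 3 did separate from it. The remaining step, an at least 1.8-fold lower number from compound 1 to compound 4 (0.27 log units; that floor lies within the scatter), is only a floor, because its starting value is a limit and not a number: the limit of > 50000 nM in this assay, at which 1 of the 4 values shown sits.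

As far as these compounds go, whether an amine, a carboxylic acid or a longer chain at this position would move the number beyond the scatter remains open. So does whether isopropyl would behave the same way elsewhere on this ring.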